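Sulfonyl-linked anilides: hydroxyphenyl to methyl(phenyl)amino swap

The compounds below may be only part of what the source reports. "The series", "measured", "known", "first", "only" and "open" are said of these compounds alone.

Measured so far:
- compound 1, `CC(O)(C(=O)Nc1ccc(S(=O)(=O)c2ccccc2O)cc1)C(F)(F)F`: 3090 nM
- compound 2, `Cc1cc(NC(=O)C(C)(O)C(F)(F)F)ccc1S(=O)(=O)c1ccccc1`: 1600 nM

Both compounds were run in a functional assay (Cavia porcellus) with sulfonylurea receptors; K-ATP channels (Homo sapiens) as the target; on this read-out higher numbers stand for weaker inhibition and lower numbers for stronger inhibition. Compound 1 gives 3090 nM, the highest of the two numbers; compound 2 gives 1600 nM, and the gap between them lies within the scatter, so the two cannot be ordered on these numbers. Both share the trifluoromethyl-bearing hydroxy amide on an anilide that carries a sulfonyl group.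

Compound 3, `CN(c1ccccc1)S(=O)(=O)c1ccc(NC(=O)C(C)(O)C(F)(F)F)cc1`, has not yet been measured. Relative to compound 1 it differs at one place:

methyl(phenyl)amino in place of 2-hydroxyphenyl on a sulfonyl sulfur

Among the compounds with values here, no step between measured compounds touches this part of the molecule, so there is no number to lean on for the direction. The change is expected to give a step in this assay of about a 1.2-fold lower number from compound 1 to compound 3 (0.09 log units; within the scatter), which is no more than the scatter, with no clear direction.

On that basis compound 3 is estimated at 2500 nM in this assay, with a range from 800 nM to 8000 nM.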

Compound 3, half-maximal inhibitory concentration: 2000 nM
Compound 3: the middle estimate sits 1.3-fold (0.10 log units) above what was measured; measured number inside the range.
By their numbers in this assay, from the lowest: compounds 2, 3 and 1 (each within the scatter of the next).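

In this assay the exchange of 2-hydroxyphenyl for methyl(phenyl)amino on a sulfonyl sulfur gives a 1.5-fold lower number from compound 1 to compound 3 (0.19 log units; within the scatter) and so does not separate the two compounds. Within the data shown here, this is the first step read at this place, and it shows that a group with 0 hydrogen-bond donors and 0 hydrogen-bond acceptors, joined to the sulfur through nitrogen rather than through an aromatic carbon, gives a number within the scatter of that of the 2-hydroxyphenyl compound, so in this single pair the hydroxyl is not needed to keep the read-out in the same range. No measurement at hand bears on why the two compounds read alike.

Among these compounds, compound 2 differs from compound 1 and from compound 3 in more than one place, so it gives no further step at this position, and a single pair within the scatter cannot show how much this place matters overall. Still open, on these data alone, is what a phenylamino group without the methyl, a plain amine, a morpholine or a 2-methoxyphenyl group on the sulfonyl sulfur would give.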